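Ethyl Ester to Chlorophenyl Ketone on the Sulfur Chain

The source may hold more compounds than are shown below. What is called first, only, known or untested is meant among the compounds shown, and "the series" means these compounds.

Compound 1 `Cc1nnc(SCc2ccccc2)n1N1C(=O)c2ccccc2C1=O` — in a functional assay on PC-3M cells (Homo sapiens) for cytotoxicity, read by MTT assay, with a stated time of 48 h (on this read-out lower numbers stand for stronger inhibition and higher numbers for weaker inhibition), compound 1 gives > 200000 nM, which is a limit of the assay and not a number.
Compound 2 `CCOC(=O)CSc1nnc(C)n1N1C(=O)c2ccccc2C1=O` — in this assay compound 2 gives > 200000 nM, again a limit rather than a number.

Compound 2 thus stands only at the limit, the point described by the limit of > 200000 nM in this assay, at which 2 of the 2 values shown sit. Going by the values given here, the single step joining the measured pair, a step that the two limits leave unreadable from compound 1 to compound 2, cannot be sized: both of its ends are limits. Compound 3 `Cc1nnc(SCC(=O)c2ccc(Cl)cc2)n1N1C(=O)c2ccccc2C1=O` differs from compound 2 by 4-chlorophenyl in place of ethoxy on a carbonyl carbon. Among the compounds with values here, the only measured step that bears on this change is unreadable, so it offers neither a direction nor a size. With nothing readable to lean on, the expected step is an at least 1.3-fold lower number from compound 2 to compound 3 (0.12 log units; that floor lies within the scatter), which is not expected to go beyond the scatter. For compound 3 the estimate in this assay is 150000 nM, with a range from 40000 nM to 400000 nM, and a large chance that again only a limit is reported.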

Compound 3, half-maximal inhibitory concentration: > 200000 nM
Compound 3 was reported as a limit; the forecaster's own chance of this, stated with the estimate: 65%; middle value at least 1.3-fold (0.12 log units) from the limit.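

Going by these compounds alone, compound 3 also gives a limit and not a number, so no step among compound 1, compound 2 and compound 3 can be read: the limit of > 200000 nM in this assay, at which 3 of the 3 values shown sit. The compounds shown leave open whether any change on the sulfur chain can give a measurable number in this assay and how large its effect would be.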